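The source may report more compounds than this note shows. Statements on the series, on what has been measured and on what is new or still open speak of the compounds shown alone.

Compound 1 `COc1ccc([C@@H]2C/C(=N/OCc3cn(-c4ccc(O)cc4)nn3)c3cc(CC=C(C)C)c(OC)cc3O2)cc1` carries a 1-(4-hydroxyphenyl)-1H-1,2,3-triazol-4-yl group on a saturated chain carbon bound to an oxygen. In a functional assay on PC-3 cells (Homo sapiens) for inhibition, read by sulforhodamine B assay, with a stated time of 48 h, tested at 50 uM (a higher number here means more inhibition of growth at the concentration tested, a lower number less inhibition of growth), compound 1 gives 64%, the second highest of three numbers. The highest number belongs to compound 2 `COc1ccc([C@@H]2C/C(=N/OCc3cn(-c4ccccc4CO)nn3)c3cc(CC=C(C)C)c(OC)cc3O2)cc1`, which gives 100%. The lowest number belongs to compound 3 `COc1ccc([C@@H]2C/C(=N/OCc3cn(-c4ccc(NC(=O)c5ccccc5)cc4)nn3)c3cc(CC=C(C)C)c(OC)cc3O2)cc1`, which gives 22%.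

Compound 4 `C#CCO/N=C1/C[C@@H](c2ccc(OC)cc2)Oc2cc(OC)c(CC=C(C)C)cc21` has not yet been measured. It keeps the core of compound 1 but swaps that whole group for a far smaller one: ethynyl in place of 1-(4-hydroxyphenyl)-1H-1,2,3-triazol-4-yl on a saturated chain carbon bound to an oxygen.

Within the data shown here, two measured steps bear on this change, though only indirectly. Putting 2-(hydroxymethyl)phenyl in place of 4-hydroxyphenyl on an aromatic nitrogen gave a number 36 percentage points higher from compound 1 to compound 2 (beyond the scatter). Putting benzamido in place of hydroxy on an aromatic carbon gave a number 42 percentage points lower from compound 1 to compound 3 (beyond the scatter). Both steps are large, but they run in opposite directions, and both compounds keep the five-membered aromatic ring. Among the measured compounds shown here, no measured compound shows what happens when both rings leave together, so the direction is poorly defined. A moderate step with only a weak lean downward is expected, and a large step either way remains possible. The estimated change is a number 14 percentage points lower from compound 1 to compound 4 (beyond the scatter). Compound 4 is expected to give 50%, with an estimated range from 20% to 85%.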

Compound 4, percent growth inhibition at one concentration: 41%
Beside the measured number, compound 4's estimate is 9 percentage points above it; the range from low to high includes it.
By their numbers in this assay, from the lowest: compound 3; then compound 4; then compound 1; then compound 2.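

In this assay, replacing the whole 1-(4-hydroxyphenyl)-1H-1,2,3-triazol-4-yl group with ethynyl gives a number 23 percentage points lower from compound 1 to compound 4 (beyond the scatter). The earlier compounds shown here all kept the five-membered aromatic ring, so they could not show that growth inhibition survives without it: compound 4 still gives 41% with neither ring present and only a two-carbon group in their place. The large group therefore adds to the inhibition at this position but is not required for it, and nothing measured here explains the size of this step.

The compounds shown leave open which part of the departing group matters, the five-membered aromatic ring, the six-membered aromatic ring or the hydroxy group, as all three leave together in this one change. A triazole carrying only a methyl group, or an aminomethyl group or a longer chain such as propyl in place of ethynyl, would help separate these parts and show how much of the difference depends on the rings.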